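This account rests on a few compounds, and the source may have more. Where it says the series, first, only, none or still open, it means among the compounds named here.

Compound 1 `COc1cccc(-c2cc(-c3cc(C(C)C)c(O)cc3C)[nH]c(=O)c2C#N)c1` and compound 2 `COc1cc(-c2cc(-c3cc(C(C)C)c(O)cc3C)[nH]c(=O)c2C#N)ccc1O` share one core and were both tested in a functional assay for inhibition, tested at 80 ug/mL; on this read-out higher numbers stand for a stronger effect at the one concentration tested and lower numbers for a weaker effect. In this assay compound 1 gives 43% and compound 2 gives 42%. Among the two numbers shown, compound 2 stands nearest compound 1, and the step of a number 1 percentage points lower from compound 1 to compound 2 (within the scatter) is within the scatter, so the two cannot be set apart. Compound 3 `Cc1cc(O)c(C(C)C)cc1-c1cc(-c2ccco2)c(C#N)c(=O)[nH]1` has not yet been measured. It differs from compound 2 in one place: furan-2-yl in place of 4-hydroxy-3-methoxyphenyl on an aromatic carbon. Going by the values given here, the single measured step, a number 1 percentage points lower from compound 1 to compound 2 (within the scatter), concerns a different change, hydroxy in place of hydrogen on an aromatic carbon, and so offers no guide to swapping one aryl ring for another. Without such a guide, compound 3 is expected to stay near the number of compound 2, and the expected step is a number 6 percentage points lower from compound 2 to compound 3 (within the scatter). Compound 3 is therefore estimated at 36%, with a wide range from 10% to 60%.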

Compound 3, a percentage reported as inhibition, at one concentration (the size of the read-out at that concentration, not a potency): 64%
For compound 3 the middle estimate is 28 percentage points below the measured one, outside the stated range (above it).
By their numbers in this assay, from the lowest: compounds 2 and 1 (each within the scatter of the next); then compound 3.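

At this place on the shared core, opposite the ring nitrogen, the choice of ring does change the read-out in this assay: furan-2-yl in place of 4-hydroxy-3-methoxyphenyl gives a number 22 percentage points higher from compound 2 to compound 3 (beyond the scatter), and furan-2-yl in place of 3-methoxyphenyl gives a number 21 percentage points higher from compound 1 to compound 3 (beyond the scatter). Going by these compounds alone, the hydroxy change between the two phenyl compounds gave no difference that could be read, so this is the first change here to move the number beyond the scatter. Nothing available explains why the furan-2-yl compound reads higher.

Going by these compounds, it remains open whether this rise is particular to furan-2-yl, or whether another five-membered ring such as thiophene, or a simple amine or methyl group at this place, would read as high. Each number also comes from a single concentration, so none of them is a potency.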